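This account rests on a few compounds, and the source may have more. Where it says the series, first, only, none or still open, it means among the compounds named here.

In a functional assay on HeLa cells (Homo sapiens) for antiproliferative activity, read by MTT assay, with a stated time of 72 h (a lower number here means a stronger inhibitor, a higher number a weaker inhibitor), compound 2 `N=C(NS(=O)(=O)c1ccccc1Cl)N1CCN(c2cc3c(cc2F)c(=O)c(C(=O)O)cn3C2CC2)CC1` gives 32 nM. It stands level with compound 1 `CCn1cc(C(=O)O)c(=O)c2cc(F)c(N3CCN(C(=N)NS(=O)(=O)c4ccccc4Cl)CC3)cc21`, which gives 32 nM, and with compound 3 `CCn1cc(C(=O)O)c(=O)c2cc(F)c(N3CCN(C(=N)NS(=O)(=O)c4ccccc4)CC3)cc21`, which gives 32 nM. Compound 4 `N=C(NS(=O)(=O)c1ccccc1C(F)(F)F)N1CCN(c2cc3c(cc2F)c(=O)c(C(=O)O)cn3C2CC2)CC1` differs from compound 2 in one place, with trifluoromethyl in place of chloro on an aromatic carbon, ortho to a large group, so that 2-chlorophenyl becomes 2-(trifluoromethyl)phenyl (trifluoromethyl in place of chloro on an aromatic carbon).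

Within the data shown here, two measured steps bear on this change. Hydrogen in place of chloro on that same aromatic carbon shows no change at the digits printed from compound 1 to compound 3 (within the scatter), and this is the main ground for expecting little here. Cyclopropyl in place of ethyl on an aromatic nitrogen, a change elsewhere in the molecule, shows no change at the digits printed from compound 1 to compound 2 (within the scatter). Neither step lies beyond the scatter. Among the measured compounds shown here, still, no measured compound carries trifluoromethyl, so the entering group itself remains untested, and the range is kept wide on both sides. The expected outcome in this assay is no change at the digits printed from compound 2 to compound 4 (within the scatter), with no shift beyond the scatter in either direction. Compound 4 is estimated at 32 nM, with an expected range from 14 nM to 75 nM.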

Compound 4, half-maximal inhibitory concentration: 32 nM
Estimate against measurement, compound 4: no gap at the digits printed; measured number inside the range.
By their numbers in this assay, from the lowest: compounds 1, 2, 3 and 4 (each within the scatter of the next).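

In this assay, trifluoromethyl in place of chloro on an aromatic carbon, ortho to a large group, gives no change at the digits printed from compound 2 to compound 4 (within the scatter), even though the entering group has four heavy atoms and the leaving group only one. The earlier compounds had shown only the removal of chloro at this place, with no change at the digits printed from compound 1 to compound 3 (within the scatter), and that step was read with an ethyl group on the aromatic nitrogen; the new step adds a replacement by a larger group, read with cyclopropyl there instead, and it too stays within the scatter. Nothing in the data given explains why these replacements leave the reading in place.

On these data alone, the position has so far been tested only with hydrogen, chloro and trifluoromethyl, so it remains open whether an amine, a methoxy group or a longer chain such as butyl on this aromatic carbon would also leave the value in place. As far as these compounds go, it is equally open whether any of these groups would behave the same way with both ethyl and cyclopropyl on the aromatic nitrogen, since each change at this carbon has been read with only one of the two.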